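From Methyl to Nitro on the Shared Core

The source may report more compounds than this note shows. Statements on the series, on what has been measured and on what is new or still open speak of the compounds shown alone.

In a functional assay on K562 cells (Homo sapiens) for inhibition, read by sulforhodamine B assay, with a stated time of 48 h (on this read-out higher numbers stand for weaker inhibition of growth and lower numbers for stronger inhibition of growth), compound 2 `Cc1ccc(-c2c(CNC(C)(C)C)c(C(=O)O)nn2-c2ccc(Cl)cc2)cc1` stands at > 629000 nM, which is a limit of the assay and not a number. The chloro counterpart, compound 1 `CC(C)(C)NCc1c(C(=O)O)nn(-c2ccc(Cl)cc2)c1-c1ccc(Cl)cc1`, gives a true number of 290000 nM. The next analogue, compound 3 `CC(C)(C)NCc1c(C(=O)O)nn(-c2ccc(Cl)cc2)c1-c1ccc([N+](=O)[O-])cc1`, carries nitro in place of methyl on an aromatic carbon, a change from 4-methylphenyl to 4-nitrophenyl. For the measured compounds named here, the one measured step that bears on this change is an at least 2.1-fold higher number from compound 1 to compound 2 (0.33 log units; beyond the scatter), which lies beyond the scatter and involves the same aromatic carbon. Going by the values given here, no measured step involves nitro, so the guide is weak. With compound 1 at 290000 nM as the nearest reference, a modest move toward stronger inhibition of growth is expected, and an at least 1.7-fold lower number from compound 2 to compound 3 (0.25 log units; that floor lies within the scatter) is the estimated step. For compound 3 the estimate is 350000 nM, with an expected range from 120000 nM to 800000 nM.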

Compound 3, concentration for 50% growth inhibition: 158000 nM
Compound 3: middle estimate off by 2.2-fold (0.35 log units), on the high side; measured number inside the range.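

At this position, on an aromatic carbon para to a large group, the change from methyl to nitro gives the first step toward stronger inhibition of growth in this assay, with an at least 3.9-fold lower number from compound 2 to compound 3 (0.59 log units; beyond the scatter). Compound 2 stands at a limit of the assay and not at a number: the limit of > 629000 nM in this assay, at which 1 of the 3 values shown sits. Nitro and chloro at this place cannot be told apart, with a 1.8-fold lower number from compound 1 to compound 3 (0.26 log units; within the scatter), so among these three compounds methyl alone stands apart from the other two groups.

The compounds shown leave open how an amine, a carboxylic acid or a longer chain would read at this place, and whether plain hydrogen there would fall with methyl or with chloro and nitro. They also leave open whether these steps hold when the shared core changes elsewhere.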